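Bromo for Fluoro on an Inactive Urea Core

The source may report more compounds than this note shows. Statements on the series, on what has been measured and on what is new or still open speak of the compounds shown alone.

Compound 1 `COc1ccccc1NC(=O)NC1CC(C)(C)Oc2ccc(Br)cc21`: in a functional assay (aorta) with Rattus norvegicus as the target (on this read-out lower numbers stand for an effect already at smaller amounts and higher numbers for an effect only at larger amounts of compound), compound 1 reaches only the limit > 10000 nM.
Compound 2 `CC1(C)CC(NC(=O)Nc2ccc(Cl)cc2)c2cc(F)ccc2O1`: in this assay compound 2 reaches only the limit > 30000 nM.

Compound 2 thus stands at a limit of the assay, with no number of its own, and the other value shown is a limit too, the limit of > 10000 nM in this assay, at which 1 of the 2 values shown sits, and (the limit of > 30000 nM in this assay, at which 1 of the 2 values shown sits). Compound 3 `CC1(C)CC(NC(=O)Nc2ccc(Cl)cc2)c2cc(Br)ccc2O1` differs from compound 2 by bromo in place of fluoro on an aromatic carbon. Within the data shown here, no step between measured compounds sizes such a change. With both measured values at limits, the step from compound 2 to compound 3 is expected to be a number no higher from compound 2 to compound 3 (the limit leaves the size open), none beyond the scatter. Compound 3 is therefore estimated at 30000 nM, in the range 10000 nM to 100000 nM, most likely again as a limit.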

Compound 3, half-maximal effective concentration: > 300000 nM
Compound 3 was reported as a limit; the forecaster's own chance of this, stated with the estimate: 80%; at least 10-fold (1.00 log units) between middle value and limit.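

Among these compounds, compound 3, like compound 1 and compound 2, stands only at a limit in this assay, so no step from either compound to compound 3 can be read. On these data alone, whether bromo in place of fluoro changes the effect at all stays open.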